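Series notes: acetyl leaves, trifluoromethyl enters on the pendant aryl

The source may report more compounds than this note shows. Statements on the series, on what has been measured and on what is new or still open speak of the compounds shown alone.

Two compounds of the series have been run in a functional assay on MCF7 cells (Homo sapiens) for inhibition, read by sulforhodamine B assay, with a stated time of 48 h, tested at 10 uM; a higher number here means more inhibition at the concentration tested (going by the name of the read-out), a lower number less inhibition. Compound 1 `c1ccc(-c2cn3ccnc3c(-c3ccc4ncn(C5CCCCC5)c4c3)n2)cc1`, which carries an unsubstituted phenyl, gives 38% in this assay. Among the compounds with values here, compound 2 `CC(=O)c1ccc(-c2cn3ccnc3c(-c3ccc4ncn(C5CCCCC5)c4c3)n2)cc1` gives 12% in this assay and so stands lowest of the two numbers, with compound 1 as its only and nearest neighbour. Within the data shown here, the single measured step in hand is a number 26 percentage points lower from compound 1 to compound 2 (beyond the scatter). Compound 3 `FC(F)(F)c1cccc(-c2cn3ccnc3c(-c3ccc4ncn(C5CCCCC5)c4c3)n2)c1` has not yet been measured. It differs from compound 2 in one place: 3-(trifluoromethyl)phenyl in place of 4-acetylphenyl on an aromatic carbon. Among the measured compounds shown here, the step from compound 1 to compound 2 bears on this change only in part, since it covers removal of the acetyl but says nothing about a trifluoromethyl group; no measured pair tests that group. Loss of the acetyl points back toward the level of compound 1, while the trifluoromethyl remains an open question, so the range is kept wide. Compound 3 is expected to move by a number 18 percentage points higher from compound 2 to compound 3 (beyond the scatter) in this assay. The estimate for compound 3 in this assay is 30%, with a range from 10% to 50%.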

Compound 3, a percentage reported as inhibition, at one concentration (the size of the read-out at that concentration, not a potency): 19.9%
The estimate for compound 3 lay 10.1 percentage points above the measured number, within the range that was stated.
By their numbers in this assay, from the lowest: compounds 2 and 3 (each within the scatter of the next); then compound 1.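

In this assay, 3-(trifluoromethyl)phenyl in place of 4-acetylphenyl on this aromatic carbon gives a number 7.9 percentage points higher from compound 2 to compound 3 (within the scatter) and so leaves the two substituted aryl groups indistinguishable at this position. Within the data shown here, the first measured pair for trifluoromethyl, read against the unsubstituted phenyl, gives a number 18.1 percentage points lower from compound 1 to compound 3 (beyond the scatter) and shows that the loss seen with the acetyl is not unique to that group: both substituted compounds, compound 2 and compound 3, stand beyond the scatter under compound 1, and neither goes against this within these three compounds. Nothing measured here bears on the reason for this shared loss of inhibition.

From the compounds shown here alone, it remains open whether the loss follows the substituent itself or where it sits on the phenyl, as 4-acetylphenyl and 3-(trifluoromethyl)phenyl differ in both the group and its place on the ring. Going by these compounds, how a phenyl carrying an amine or a carboxylic acid would behave at this position also remains open, as does whether any substituent on this phenyl can match or exceed the unsubstituted compound 1.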